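This account rests on a few compounds, and the source may have more. Where it says the series, first, only, none or still open, it means among the compounds named here.

Measured so far:
compound 1 `CC(=O)N(Cc1ccccc1)c1cc(C)cc(C)c1`, in an assay on HEK293 cells for displacement of a labelled ligand from Translocator protein (Homo sapiens), read by scintillation counting, with a stated time of 90 min (on this read-out lower numbers stand for stronger inhibition and higher numbers for weaker inhibition), compound 1 gives 1260 nM;
compound 2 `CC(=O)N(Cc1ccc(OCc2ccccc2)cc1)c1cc(C)cc(C)c1`, in this assay compound 2 gives 738 nM.

Going by the values given here, compound 1 stands at the higher of these two numbers, but the only step that joins them, a 1.7-fold lower number from compound 1 to compound 2 (0.23 log units; within the scatter), lies within the usual scatter, so the two compounds cannot be told apart on these figures. That step changed a position on the benzyl part of the shared core.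

Compound 3 `CCN(CC)C(=O)CN(Cc1ccccc1)c1cc(C)cc(C)c1` differs from compound 1 in another place: (diethylcarbamoyl)methyl in place of acetyl on a nitrogen on an aromatic ring. No measured step touches the acetyl side of the nitrogen, so nothing shown bears directly on this change, and the one step in hand, which was within the scatter, gives no direction to lean on. The expectation for compound 3 in this assay is therefore a number close to that of compound 1, with a wide range, and the step of a 1.4-fold lower number from compound 1 to compound 3 (0.15 log units; within the scatter) is expected to stay within the scatter. Compound 3 is estimated at 900 nM, between 250 nM and 3500 nM.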

Compound 3, inhibition constant: 4260 nM
Estimate against measurement, compound 3: 4.7-fold (0.68 log units) below, and the stated range ends below it.
By their numbers in this assay, from the lowest: compounds 2 and 1 (each within the scatter of the next); then compound 3.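

In this assay, going by these compounds alone, the group on the nitrogen makes a measurable difference: a 3.4-fold higher number from compound 1 to compound 3 (0.53 log units; beyond the scatter) is the first step to lie beyond the usual scatter, although it is modest in size. Putting (diethylcarbamoyl)methyl in place of acetyl on this nitrogen therefore gives weaker inhibition, whereas the change on the benzyl part, a 1.7-fold lower number from compound 1 to compound 2 (0.23 log units; within the scatter), could not be told apart from scatter. No measurement shown here explains why the number rises.

A single step cannot show whether the whole of the new group or only one part of it goes with this rise. On these data alone, it also remains open how inhibition would respond on the same nitrogen to a carboxylic acid, an amine such as dimethylaminoethyl, or a smaller amide such as carbamoylmethyl.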